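From 2-methylphenyl to 3-fluorophenyl on a shared core

The compounds below may be only part of what the source reports. "The series", "measured", "known", "first", "only" and "open" are said of these compounds alone.

Compound 1 `CCOC(=O)c1c(-c2ccccc2C)[nH]c2cc(OC)ccc2c1=O` gives > 100000 nM as a limit
Compound 2 `CCOC(=O)c1c(-c2ccc(C(F)(F)F)cc2)[nH]c2cccc(OC)c2c1=O` gives 22000 nM as a number

In a physicochemical assay for solubility, in phosphate buffer, at pH 7.4 (a higher number here means a more soluble compound, a lower number a less soluble compound), compound 1 stands at > 100000 nM as a limit of the assay and not a number. Compound 3 `CCOC(=O)c1c(-c2cccc(F)c2)[nH]c2cc(OC)ccc2c1=O` has not yet been measured. It carries 3-fluorophenyl in place of 2-methylphenyl on an aromatic carbon next to the ring nitrogen (3-fluorophenyl in place of 2-methylphenyl on an aromatic carbon). Going by the values given here, no measured step isolates this change. Since compound 2 gives 22000 nM in this assay a number is possible for compound 3 too, and a moderate fall is expected. The estimated step is an at least 1.6-fold lower number from compound 1 to compound 3 (0.22 log units; that floor lies within the scatter) in this reading, though it could go unresolved at the limit. For compound 3 the expected solubility is 60000 nM with an estimated range (20000 nM to 100000 nM).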

Compound 3, solubility: > 100000 nM
Compound 3 was reported as a limit (the forecaster's own chance of this, stated with the estimate: 35%); at least 1.6-fold (0.22 log units) between middle value and limit.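

No step can be read from compound 1 to compound 3 in this assay, since both stand at a limit and not a number: the limit of > 100000 nM in this assay, at which 2 of the 3 values shown sit.

The compounds shown leave open what 3-fluorophenyl in place of 2-methylphenyl changes on the shared core.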